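The source may hold more compounds than are shown below. What is called first, only, known or untested is meant among the compounds shown, and "the series" means these compounds.

Compound 1 `O=C(Nc1ccncc1)Nc1cc(-c2cncnc2)cc(C(F)(F)F)c1` is a diaryl urea that in a functional assay on A549 cells (Homo sapiens) for inhibition, read by MTT assay, with a stated time of 48 h (a lower number here means a stronger inhibitor, a higher number a weaker inhibitor), gives 2420 nM. Compound 2 `O=C(Nc1ccncc1)Nc1cc(-c2cncnc2)ccc1OC(F)(F)F`, in which the difference between the two cores is not broken down here, gives in this assay a value of 3750 nM, which lies within the scatter of compound 1. Compound 3 `Cn1cnc(-c2cc(NC(=O)Nc3ccncc3)cc(C(F)(F)F)c2)c1` is the result of one change to compound 1, (1-methyl-1H-imidazol-4-yl in place of pyrimidin-5-yl on an aromatic carbon), and in this assay compound 3 gives 39400 nM, so that a 16-fold higher number from compound 1 to compound 3 (1.21 log units; beyond the scatter).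

Compound 4 `Cn1cnc(-c2ccc(OC(F)(F)F)c(NC(=O)Nc3ccncc3)c2)c1` has not yet been measured. It arises from compound 2 by 1-methyl-1H-imidazol-4-yl in place of pyrimidin-5-yl on an aromatic carbon. This is the same kind of change as that from compound 1 to compound 3, not the same one: in compound 1 the position is meta to a trifluoromethyl group, whereas in compound 2 it is para to a trifluoromethoxy group. Resting on the single earlier step of a 16-fold higher number from compound 1 to compound 3 (1.21 log units; beyond the scatter), a step of comparable size is expected from compound 2 to compound 4, namely a 13-fold higher number from compound 2 to compound 4 (1.12 log units; beyond the scatter). Compound 4 is therefore estimated to give in this assay about 50000 nM, expected to fall between 15000 nM and 150000 nM.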

Compound 4, half-maximal inhibitory concentration: 79300 nM
Compound 4: middle estimate off by 1.6-fold (0.20 log units), on the low side, and the stated range covers the measured number.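

On the core of compound 2, the change from pyrimidin-5-yl to 1-methyl-1H-imidazol-4-yl again goes with a large shift toward weaker inhibition, a 21-fold higher number from compound 2 to compound 4 (1.33 log units; beyond the scatter). Set beside the earlier step, its size carries over between the two cores in this assay: the same change on two cores in this assay, a 16-fold higher number (1.21 log units; beyond the scatter) from compound 1 to compound 3 and a 21-fold higher number (1.33 log units; beyond the scatter) from compound 2 to compound 4, 1.3-fold (0.11 log units) apart, within the scatter of two such steps. Going by these compounds alone, this shows that the step holds on one core with a trifluoromethyl group and on one with a trifluoromethoxy group, but with only two pairs it does not show that it would hold on any other core, and it gives no reason for the step.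

The compounds shown leave open how a phenyl group or an amine such as morpholine would compare with these two groups on the same aromatic carbon. As far as these compounds go, it also remains open whether the step would keep its size if a nitrile or a carboxylic acid stood in place of the trifluoromethyl or trifluoromethoxy group.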